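Exchanging the Terminal Aromatic Ring on a Shared Core

The compounds below may be only part of what the source reports. "The series", "measured", "known", "first", "only" and "open" are said of these compounds alone.

In a functional assay on SK-OV-3 cells (Homo sapiens) for cytotoxicity (a higher number here means a weaker inhibitor, a lower number a stronger inhibitor), compound 3 `C=C/C=C\[C@H](C)[C@H](OC(N)=O)[C@@H](C)[C@H](O)[C@@H](C)C/C(C)=C\[C@H](C)[C@@H](O)[C@@H](C)/C=C\CCc1sccc1C` gives 370 nM. Compound 1 `C=C/C=C\[C@H](C)[C@H](OC(N)=O)[C@@H](C)[C@H](O)[C@@H](C)C/C(C)=C\[C@H](C)[C@@H](O)[C@@H](C)/C=C\CCc1cccc(F)c1` gives 400 nM and compound 2 `C=C/C=C\[C@H](C)[C@H](OC(N)=O)[C@@H](C)[C@H](O)[C@@H](C)C/C(C)=C\[C@H](C)[C@@H](O)[C@@H](C)/C=C\CCc1ccc(C)c(O)c1` gives 410 nM, so compound 3 holds the lowest of the three numbers shown, though each gap to it lies within the scatter. Compound 4 `C=C/C=C\[C@H](C)[C@H](OC(N)=O)[C@@H](C)[C@H](O)[C@@H](C)C/C(C)=C\[C@H](C)[C@@H](O)[C@@H](C)/C=C\CCc1ccsc1` differs from compound 3 at one place, on a saturated chain carbon, two bonds along the chain from a double-bonded chain carbon: thiophen-3-yl in place of 3-methylthiophen-2-yl on a saturated chain carbon, two bonds along the chain from a double-bonded chain carbon. Earlier exchanges of the ring at this place left the number essentially unchanged, with a 1.0-fold higher number from compound 1 to compound 2 (0.01 log units; within the scatter), a 1.1-fold lower number from compound 1 to compound 3 (0.03 log units; within the scatter) and a 1.1-fold lower number from compound 2 to compound 3 (0.04 log units; within the scatter). A further exchange of that ring is therefore expected to give no step beyond the scatter, the expected step being a 1.1-fold higher number from compound 3 to compound 4 (0.03 log units; within the scatter). Compound 4 is estimated at 400 nM, within a range from 200 nM to 800 nM.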

Compound 4, half-maximal inhibitory concentration: 440 nM
Beside the measured number, compound 4's estimate is 1.1-fold (0.04 log units) below it; the range from low to high includes it.
By their numbers in this assay, from the lowest: compounds 3, 1, 2 and 4 (each within the scatter of the next).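

In this assay, an unsubstituted thiophene ring with 5 heavy atoms, thiophen-3-yl, replaces the 6 heavy atoms of 3-methylthiophen-2-yl and gives a 1.2-fold higher number from compound 3 to compound 4 (0.08 log units; within the scatter). The two benzene-ring compounds compare the same way, with a 1.1-fold higher number from compound 2 to compound 4 (0.03 log units; within the scatter) and a 1.1-fold higher number from compound 1 to compound 4 (0.04 log units; within the scatter). So this position accepts a thiophene ring without the methyl group and attached through a different ring carbon, with every step inside the scatter, and nothing available explains this. Still open, going by these compounds, is whether an amine or a carboxylic acid on this ring, or a longer chain leading to it, would shift the number beyond the scatter.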